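A side-group swap on compound 1

The source may hold more compounds than are shown below. What is called first, only, known or untested is meant among the compounds shown, and "the series" means these compounds.

Measured so far in a physicochemical assay for lipophilicity, at pH 7.4; on this read-out higher numbers stand for higher lipophilicity and lower numbers for lower lipophilicity:
- compound 1 `Cc1cc(C(=O)NN2CCCCC2)nn1Cc1cc(Cl)ccc1OCC(C)C`: 3.3
- compound 2 `Cc1cc(NC(=O)c2c(F)cccc2F)nn1Cc1cc(Cl)ccc1OCc1ccccc1`: > 3.7 (a limit, not a number)

Only compound 1 has an exact number in this assay, standing at 3.3. The result for compound 2 is a limit. Among the compounds with values here, no step between two measured compounds is available, so the comparison below has no direct precedent.

The next compound is compound 3 `Cc1cc(NC(=O)OC(C)C)nn1Cc1cc(Cl)ccc1OCC(C)C`, which keeps the rest of compound 1 unchanged. It carries (isopropoxycarbonyl)amino in place of (piperidin-1-yl)carbamoyl on an aromatic carbon. The six-membered non-aromatic ring leaves with this swap, and no ring enters.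

Compound 3 shares an amino link to its carbonyl with compound 2, which reports the limit > 3.7. That one limit is thin support, yet it tips the expectation slightly upward in this assay. The expected step is small, about the size of ordinary scatter: a number 0.30 log units higher from compound 1 to compound 3 (within the scatter). For compound 3 the estimated value is 3.6, with an expected range from 3.2 to 4.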

Compound 3, distribution coefficient: > 3.7
Compound 3: no number, only a limit; the forecaster's own chance of this, stated with the estimate: 25%; middle value at least 0.10 log units away from the limit.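

Within the data shown here, this is the first step that can be read at this position of the shared core: in this assay, (isopropoxycarbonyl)amino in place of (piperidin-1-yl)carbamoyl on an aromatic carbon gives a number at least 0.40 log units higher from compound 1 to compound 3 (beyond the scatter), while the count of hydrogen-bond donors and acceptors is the same on both sides of the swap. Compound 3 gives > 3.7, which is a limit and not a number. The step therefore marks only the smallest change that fits the result, and its full size stays unknown, since the read-out stops at a mark shared with another compound: the limit of > 3.7 in this assay, at which 2 of the 3 values shown sit.

The loss of the six-membered non-aromatic ring and the arrival of the isopropoxycarbonyl group happen in one swap, and the compounds shown do not separate the two. From the compounds shown here alone, it also remains open how a simple amine or a carboxylic acid in the same place would read in this assay, and whether such a group would give a number rather than a limit.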